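The source may report more compounds than this note shows. Statements on the series, on what has been measured and on what is new or still open speak of the compounds shown alone.

Of the compounds shown here, three with the same core have been measured in an assay on isolated protein for inhibition of bone morphogenetic protein 1 (Homo sapiens); a higher number here means a weaker inhibitor, a lower number a stronger inhibitor. Compound 1, `COc1ccc(S(=O)(=O)N(Cc2sc3scc(C)c3c2C)[C@H](C)C(=O)NO)cc1`, gives 60 nM in this assay. Compound 2, `COc1ccc(S(=O)(=O)N(Cc2ccc(Br)cc2)[C@H](C)C(=O)NO)cc1`, gives 37 nM in this assay. Compound 3, `C=CCOc1ccc2ccc(CN([C@H](C)C(=O)NO)S(=O)(=O)c3ccc(OC)cc3)cc2c1`, gives 130 nM in this assay.

Among these three numbers, compound 2 has the lowest. The nearest is compound 1, whose number lies within the usual scatter of repeated measurements, so the two cannot be told apart on this evidence. Compound 3 stands furthest away, and that gap is beyond the scatter.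

The next compound, compound 4, `COc1ccc(S(=O)(=O)N(Cc2cccc(Br)c2)[C@H](C)C(=O)NO)cc1`, has not yet been measured in this assay. It has the same atoms as compound 2, joined differently: 3-bromophenyl in place of 4-bromophenyl on a saturated chain carbon bound to a sulfonamide nitrogen. Going by the values given here, no measured pair in this set shows this kind of change, so there is nothing to lean on beyond the values themselves.

A change that keeps the count of atoms and moves only the bromine on the ring is expected to shift the number little, if at all, and the expected step from compound 2 to compound 4 is a 1.6-fold higher number from compound 2 to compound 4 (0.21 log units; within the scatter). Compound 4 is therefore estimated at 60 nM in this assay, with a range from 20 nM to 180 nM.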

Compound 4, half-maximal inhibitory concentration: 93 nM
The estimate for compound 4 lay 1.6-fold (0.19 log units) below the measured number; the range from low to high includes it.
By their numbers in this assay, from the lowest: compounds 2, 1, 4 and 3 (each within the scatter of the next, the first and the last beyond it).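

In this assay, going by these compounds alone, putting 3-bromophenyl in place of 4-bromophenyl on a saturated chain carbon bound to a sulfonamide nitrogen gives a 2.5-fold higher number from compound 2 to compound 4 (0.40 log units; beyond the scatter), and this is the first comparison in the set between two compounds that differ in one place only. Within the data shown here, the two groups have the same atoms and the same counts, so the only difference between these compounds is where the bromine sits on the ring, and that alone is enough to move the number beyond the scatter. Nothing available here explains why the bromine's location matters to this extent.

The compounds shown leave open whether the same shift would appear with another group in the bromine's place, such as chlorine, a methyl group or an amine, or whether it belongs to bromine alone. They also leave open how a plain phenyl ring without any bromine would compare with either compound 2 or compound 4, which is the comparison needed to tell whether the bromine helps, harms or does little at each of these two locations.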